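A few compounds are considered here, and "the series" means these few. Any claim that something is new, unique, unknown or untested is made for them only; others in the source may bear on it.

Three compounds from this study share one core and differ only at their outer parts. Compound 1 `C/C(=N\N=C1/SCC(=O)N1Cc1cccc(F)c1)c1cccs1` carries a fluoro group on one of its rings. In a physicochemical assay, with a stated time of 30 min (a lower number here means a stronger inhibitor, a higher number a weaker inhibitor), compound 1 gives > 5000000 nM, which is a limit of the assay rather than a number. Compound 2 `C/C(=N/N=C1\SCC(=O)N1Cc1ccc(F)cc1)c1cccs1` is a close relative of it. In this assay compound 2 likewise gives > 5000000 nM, again a limit and not a measured number. Compound 3 `O=C1CS/C(=N\N=C2CCCC2)N1Cc1ccc(Cl)cc1` has a different ring at one end. In this assay compound 3 also returns > 5000000 nM, once more a limit. Compound 1 therefore stands exactly where its two companions stand, at the limit of > 5000000 nM in this assay, at which 3 of the 3 values shown sit. Compound 4 `C/C(=N\N=C1/SCC(=O)N1Cc1cccc(Cl)c1)c1cccs1` is not yet measured. It differs from compound 1 in one place: chloro in place of fluoro on an aromatic carbon. Going by the values given here, no measured pair here changes in this way, so there is no step to read a size from. Because every value shown sits at the limit of > 5000000 nM in this assay, at which 3 of the 3 values shown sit, the expectation is a step of a number no higher from compound 1 to compound 4 (the limit leaves the size open), none beyond the scatter. Compound 4 is accordingly estimated at 5000000 nM in this assay, within a range from 2000000 nM to 20000000 nM, and most likely the assay will again report only its limit.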

Compound 4, half-maximal inhibitory concentration: > 5000000 nM
Compound 4: only a limit was reported; the forecaster's own chance of this, stated with the estimate: 85%; the middle value sits exactly at the limit.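

No step can be read between compound 1 and compound 4, because each result is only a limit of the assay and not a number: the limit of > 5000000 nM in this assay, at which 4 of the 4 values shown sit.

The compounds shown leave open how strongly any of them inhibits in this assay, and whether going from 3-fluorophenyl to 3-chlorophenyl changes that strength at all.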